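The source may report more compounds than this note shows. Statements on the series, on what has been measured and on what is new or still open speak of the compounds shown alone.

Compound 3 `c1cncc(-c2cccc3c2CCC3c2ncc[nH]2)c1` stands at the edge of what the assay can read. In a functional assay on CHO cells for agonist activity at Alpha-1D adrenergic receptor (Homo sapiens), read by FLIPR and calcium flux (a higher number here means that more compound is needed for the effect, a lower number that less compound is needed), compound 3 gives > 10000 nM, which is a limit of the assay. Compound 1 `Cn1ccc(-c2cccc3c2CCC3c2ncc[nH]2)n1` gives in this assay the value > 10000 nM, also a limit. Compound 2 `CS(=O)(=O)Nc1cccc2c1CCC2c1ncc[nH]1` gives in this assay the value > 10000 nM, again a limit. All three values thus sit at the limit of > 10000 nM in this assay, at which 3 of the 3 values shown sit, and the steps a step that the two limits leave unreadable from compound 1 to compound 2, a step that the two limits leave unreadable from compound 1 to compound 3 and a step that the two limits leave unreadable from compound 2 to compound 3 have no readable size. Compound 4 `c1cc(-c2cn[nH]c2)c2c(c1)C(c1ncc[nH]1)CC2` differs from compound 3 by 1H-pyrazol-4-yl in place of pyridin-3-yl on an aromatic carbon. Among the measured compounds shown here, none of the measured steps bears on this change with a readable size; every comparison among compounds 1, 2 and 3 runs between two limits, so the data give no direction and no size. The expected step is a step that the limit leaves unreadable from compound 3 to compound 4, with another limit the most likely outcome. Compound 4 is expected in this assay to give about 20000 nM, within a range from 4000 nM to 100000 nM.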

Compound 4, half-maximal effective concentration: 319 nM
The estimate for compound 4 lay 63-fold (1.80 log units) above the measured number; measured number below the stated range.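

At this aromatic carbon of the shared core, the group decides whether this assay gives a readable number at all: of the four compounds, only compound 4, with 1H-pyrazol-4-yl, leaves the limit. The change is large against each of the other groups, with an at least 31-fold lower number from compound 3 to compound 4 (1.49 log units; beyond the scatter), an at least 31-fold lower number from compound 2 to compound 4 (1.49 log units; beyond the scatter) and an at least 31-fold lower number from compound 1 to compound 4 (1.49 log units; beyond the scatter). These steps give only a minimum size, since the other three compounds all stand at a limit: the limit of > 10000 nM in this assay, at which 3 of the 4 values shown sit.

The steps among compound 1, compound 2 and compound 3 remain unreadable, so these three groups cannot be ranked against one another. Also open, on these data alone, is whether 1H-pyrazol-3-yl, 1H-imidazol-4-yl, an amine or a carboxylic acid at this carbon would give a readable number too.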